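Swapping carboxy for pyrrolidinyl: expected cytotoxicity shift

The compounds below may be only part of what the source reports. "The series", "measured", "known", "first", "only" and "open" are said of these compounds alone.

Compound 3 `NC(=S)Nc1cccc(OCCCCCOc2ccc(C(=O)O)cc2)c1` is one of three measured members of this series. In an ADME assay on Ava5 cells (Homo sapiens) for cytotoxicity (on this read-out lower numbers stand for higher toxicity in this test and higher numbers for lower toxicity in this test), compound 1 `NC(=S)Nc1cccc(OCCCCCOc2ccc(F)cc2)c1` gives 5000 nM and compound 2 `NC(=S)Nc1cccc(OCCCCCOc2ccc(Cl)cc2)c1` gives 7000 nM. Compound 3 is reported only as a limit of the assay, > 50000 nM, so it stands at the top of the numbers shown. The steps leading there were an at least 10-fold higher number from compound 1 to compound 3 (1.00 log units; beyond the scatter) and an at least 7.1-fold higher number from compound 2 to compound 3 (0.85 log units; beyond the scatter), whereas a 1.4-fold higher number from compound 1 to compound 2 (0.15 log units; within the scatter).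

Compound 4 `NC(=S)Nc1cccc(OCCCCCOc2ccc(N3CCCC3)cc2)c1` is not yet measured; it differs from compound 3 by pyrrolidin-1-yl in place of carboxy on an aromatic carbon. Within the data shown here, no measured step exchanges carboxy for pyrrolidin-1-yl; the two steps that bear on it are those that brought the carboxy in, both ending at the limit of > 50000 nM in this assay, at which 1 of the 3 values shown sits. Removing the carboxy is therefore expected to reverse much of that rise, and the expected step is an at least 6.2-fold lower number from compound 3 to compound 4 (0.79 log units; beyond the scatter), downward. Compound 4 is estimated at 8000 nM, with a range from 2000 nM to 50000 nM, though a value at the limit remains possible.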

Compound 4, half-maximal cytotoxic concentration: 16000 nM
Compound 4: the middle estimate sits 2.0-fold (0.30 log units) below what was measured; the range from low to high includes it.
By their numbers in this assay, from the lowest: compounds 1 and 2 (each within the scatter of the next); then compound 4. At a limit, above all of these: compound 3.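

In this assay, among these compounds, the carboxy is not the only group at this position, on an aromatic carbon para to a large group, that moves the number above the halogen compounds: pyrrolidin-1-yl also does so, with a 2.3-fold higher number from compound 2 to compound 4 (0.36 log units; beyond the scatter) and a 3.2-fold higher number from compound 1 to compound 4 (0.51 log units; beyond the scatter). Exchanging the carboxy for this ring still lowers the number, with an at least 3.1-fold lower number from compound 3 to compound 4 (0.49 log units; beyond the scatter), which places compound 4 between compounds 1 and 2 and compound 3. The value of compound 3 is a limit, so this last step is only a bound: the limit of > 50000 nM in this assay, at which 1 of the 4 values shown sits.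

The compounds shown leave open whether an open-chain amine such as dimethylamino, or a morpholin-4-yl ring, would stay near compound 4 or drop to the level of compounds 1 and 2. They also leave open whether a methyl ester or a primary amide in place of the carboxy would keep the number near the limit of compound 3.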